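A few compounds are considered here, and "the series" means these few. Any claim that something is new, unique, unknown or untested is made for them only; others in the source may bear on it.

Measured in a functional assay on HCT-116 cells (Homo sapiens) for antiproliferative activity, read by MTT assay, with a stated time of 72 h; a higher number here means a weaker inhibitor, a lower number a stronger inhibitor:
- compound 1 `O=C(Nc1ccc(Nc2nccc(Nc3ccccc3Cl)n2)cc1)Nc1ccc(Cl)c(C(F)(F)F)c1`: 8100 nM
- compound 2 `O=C(Nc1ccc(Nc2nccc(Nc3cccc(Cl)c3)n2)cc1)Nc1ccc(Cl)c(C(F)(F)F)c1`: 4820 nM

Compound 2, at 4820 nM, cannot be separated from compound 1, since the two lie within the scatter of each other. The next compound is compound 3 `O=C(Nc1ccc(Nc2nccc(Nc3ccc(Cl)cc3)n2)cc1)Nc1ccc(Cl)c(C(F)(F)F)c1`, which has 4-chlorophenyl in place of 3-chlorophenyl on a nitrogen on an aromatic ring. Going by the values given here, one measured step bears on this change, the exchange of 2-chlorophenyl for 3-chlorophenyl at that same place, which gave a 1.7-fold lower number from compound 1 to compound 2 (0.23 log units; within the scatter). Among the compounds with values here, no measured compound yet carries 4-chlorophenyl, so this single step is a thin guide. On that evidence, no change beyond the scatter is expected in this assay, and no firm direction can be given. The estimate means an expected 1.1-fold higher number from compound 2 to compound 3 (0.06 log units; within the scatter). For compound 3 the estimated value is 5500 nM, with an expected range of 2500 nM to 12000 nM.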

Compound 3, half-maximal inhibitory concentration: 4660 nM
Compound 3: the middle estimate sits 1.2-fold (0.07 log units) above what was measured, and the stated range covers the measured number.
By their numbers in this assay, from the lowest: compounds 3, 2 and 1 (each within the scatter of the next).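

With 4-chlorophenyl in place of 3-chlorophenyl on a nitrogen on an aromatic ring, this assay shows a 1.0-fold lower number from compound 2 to compound 3 (0.01 log units; within the scatter) and, against 2-chlorophenyl at the same place, a 1.7-fold lower number from compound 1 to compound 3 (0.24 log units; within the scatter). All three chlorophenyl groups now lie within the scatter of one another, so in this series and this assay the place of the chlorine on that ring separates none of the three compounds. Nothing available offers an explanation for this result.

From the compounds shown here alone, whether this position responds to anything other than a chlorophenyl remains open, since a plain phenyl, a methoxyphenyl, a pyridyl ring or an alkyl amine could behave differently. Going by these compounds, all three compounds also share the rest of the structure, so it is equally open whether the same result would hold with another group in place of the 4-chloro-3-(trifluoromethyl)phenyl on the urea.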